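The compounds below may be only part of what the source reports. "The series", "measured", "known", "first", "only" and "open" are said of these compounds alone.

Compound 1 `Cc1ccccc1-c1nc(CN2CCC(C(=O)NCCCN3CCC(C(C)C)CC3)CC2)c(C)o1` was tested in a physicochemical assay for solubility, in phosphate buffer, measured as kinetic solubility, at pH 7.4 (on this read-out higher numbers stand for higher solubility and lower numbers for lower solubility), and its result is a limit of the assay rather than a number: compound 1 gives > 71 ug/mL. Compound 2 `Cc1oc(-c2ccc(Cl)cc2)nc1CN1CCC(C(=O)NCCCN2C[C@H](C)C[C@H](C)C2)CC1` in this assay also gives only a limit, > 72 ug/mL. Compound 3 `Cc1oc(-c2c(Cl)cccc2Br)nc1CN1CCC(C(=O)NCCCN2C[C@H](C)C[C@H](C)C2)CC1` in this assay likewise gives a limit, > 83 ug/mL. Compounds 2 and 3 differ in one place, 2-bromo-6-chlorophenyl in place of 4-chlorophenyl on an aromatic carbon, and the step between them is a step that the two limits leave unreadable from compound 2 to compound 3. Compound 1 therefore cannot be placed above or below the others on the numbers shown; all three sit at a limit, as the limit of > 71 ug/mL in this assay, at which 1 of the 3 values shown sits, the limit of > 72 ug/mL in this assay, at which 1 of the 3 values shown sits, and the limit of > 83 ug/mL in this assay, at which 1 of the 3 values shown sits, record.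

Compound 4 `Cc1ccccc1-c1nc(CN2CCC(C(=O)NCCN3C[C@H](C)C[C@H](C)C3)CC2)c(C)o1` differs from compound 1 in one place: 3,5-dimethylpiperidin-1-yl in place of (4-isopropylpiperidin-1-yl)methyl on a saturated chain carbon, two bonds along the chain from an amide-type nitrogen. Among the measured compounds shown here, no measured step follows this change directly. What the data offer is that compound 2 carries the same 3,5-dimethylpiperidin-1-yl group on a longer chain and sits at the limit of > 72 ug/mL in this assay, at which 1 of the 3 values shown sits, and compound 3, with that group as well, sits at the limit of > 83 ug/mL in this assay, at which 1 of the 3 values shown sits. The expected step is therefore a step that the limit leaves unreadable from compound 1 to compound 4, none beyond the scatter. Compound 4 is expected to give 80 ug/mL in this assay, within a range from 45 ug/mL to 150 ug/mL, most likely again reported only as a limit.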

Compound 4, solubility: > 67 ug/mL
Compound 4: no number, only a limit; the forecaster's own chance of this, stated with the estimate: 80%; the middle value is on the limit's open side.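

In this assay compound 4 gives > 67 ug/mL, which is a limit of the assay and not a number. Compound 1 also gives only a limit, so the step between compound 1 and compound 4 cannot be read. The compounds shown leave open how far any of them lies past its limit, and whether 3,5-dimethylpiperidin-1-yl in place of (4-isopropylpiperidin-1-yl)methyl makes any difference in this assay.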